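The source may hold more compounds than are shown below. What is called first, only, known or untested is meant among the compounds shown, and "the series" means these compounds.

Measured so far:
Compound 1, `CCCNc1cc(-c2ccccc2)c(=O)[nH]n1`: in an assay for inhibition of casein kinase I isoform alpha (Sus scrofa), read by scintillation counting and 33P incorporation, with a stated time of 30 min, in the presence of a further agent that is not named here (on this read-out lower numbers stand for stronger inhibition and higher numbers for weaker inhibition), compound 1 gives > 10000 nM, which is a limit of the assay and not a number.
Compound 2, `CCCNc1n[nH]c(=O)cc1-c1ccccc1`: compound 2 gives > 10000 nM, again a limit.
Compound 3, `CC(=O)Nc1n[nH]c(=O)cc1-c1ccccc1`: compound 3 gives > 10000 nM, also a limit.

Compounds 1 and 2 are built from the same atoms joined differently; the difference between the two cores is not broken down here. Compound 3 arises from compound 2 by one change, (acetyl in place of propyl on a nitrogen on an aromatic ring). The size of that step, a step that the two limits leave unreadable from compound 2 to compound 3, cannot be read, because both values sit at the limit of > 10000 nM in this assay, at which 3 of the 3 values shown sit.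

The unmeasured compound 4, `CC(=O)Nc1cc(-c2ccccc2)c(=O)[nH]n1`, applies the same change to compound 1: acetyl in place of propyl on a nitrogen on an aromatic ring. Nothing among the three measured compounds shows a readable effect of this change. The step is expected to be a step that the limit leaves unreadable from compound 1 to compound 4, and this rests on compound 1 sitting at the limit > 10000 nM together with the unreadable a step that the two limits leave unreadable from compound 2 to compound 3. Compound 4 is therefore estimated at 20000 nM, most likely reported again only as a limit, within 8000 nM to 100000 nM.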

Compound 4, half-maximal inhibitory concentration: > 10000 nM
Compound 4 ended at the assay's limit (the forecaster's own chance of this, stated with the estimate: 85%); the middle value lies beyond the limit too.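

No step can be read from compound 1 to compound 4, because both values are limits of the assay and not numbers: the limit of > 10000 nM in this assay, at which 4 of the 4 values shown sit.

The compounds shown leave open whether replacing propylamino with acetamido changes inhibition in this assay at all, and whether either core can give a readable value there.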